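Swapping the pyrimidinyl arm for a bicyclic amine

The source may report more compounds than this note shows. Statements on the series, on what has been measured and on what is new or still open speak of the compounds shown alone.

Compound 1 `c1cnc(CN(CCCN2CCNCC2)[C@H]2CCCc3cccnc32)nc1` is the benchmark here. Among the measured compounds shown here, in an ADME assay on microsomes from liver (Mus musculus) for metabolic stability, read by LC-MS, with a stated time of 10 min, tested at 0.5 uM (a lower number here means that less of the compound is left, a higher number that more of the compound is left), compound 1 gives 78%, the highest of the three numbers known. For the measured compounds named here, compound 2 `CCN1CCN(CCCN(C[C@H]2Cc3ccccc3CN2)[C@H]2CCCc3cccnc32)CC1` gives 19% and compound 3 `c1ccc2c(c1)CN[C@@H](CN(CCCN1CCN(C3CC3)CC1)[C@H]1CCCc3cccnc31)C2` gives 3%; these two differ from compound 1 in more than one place, so no single step links them to it. Going by the values given here, the one measured step, a number 16 percentage points lower from compound 2 to compound 3 (beyond the scatter), concerns a change that is absent from the move to compound 4 `c1cnc2c(c1)CN[C@@H](CN(CCCN1CCNCC1)[C@H]1CCCc3cccnc31)C2`. That move is a group of 10 heavy atoms (8 carbon, 2 nitrogen; one six-membered non-aromatic ring with 1 hetero atom, one six-membered aromatic ring with 1 hetero atom) in place of a group of 6 heavy atoms (4 carbon, 2 nitrogen; one six-membered aromatic ring with 2 hetero atoms), on a saturated chain carbon bound to an amine nitrogen. Among the compounds with values here, no measured step bears directly on this change, and the low numbers of compounds 2 and 3 offer only a loose hint. A clear drop is therefore expected, but an uncertain one: compound 4 is estimated at 40%, between 12% and 70%, meaning an expected step of a number 38 percentage points lower from compound 1 to compound 4 (beyond the scatter).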

Compound 4, percent of the compound remaining: 78%
Compound 4: the middle estimate sits 38 percentage points below what was measured; measured number above the stated range.
By their numbers in this assay, from the lowest: compound 3; then compound 2; then compounds 1 and 4 (each within the scatter of the next).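

Putting the group of 10 heavy atoms in place of pyrimidin-2-yl, on a saturated chain carbon bound to an amine nitrogen, gives no change at the digits printed from compound 1 to compound 4 (within the scatter) in this assay and so costs nothing measurable. This position therefore accepts a larger group that also carries a defined stereocentre, with no loss in the share of compound left. No measurement at hand explains this result. Compound 4 differs from compounds 2 and 3 in more than one place, so their low numbers cannot be traced to any single change. Going by these compounds, how a plain phenyl group on this carbon would fare stays open.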